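The source may report more compounds than this note shows. Statements on the series, on what has been measured and on what is new or still open speak of the compounds shown alone.

In a physicochemical assay for solubility, read by HPLC, in phosphate buffer, measured as kinetic solubility, at pH 7.4 (a lower number here means a less soluble compound, a higher number a more soluble compound), compound 1 `CC[C@@H](C)n1ncn(-c2ccc(N3CCN(c4ccc(OC[C@@H]5CO[C@](C)(c6ccc(Cl)cc6Cl)O5)cc4)CC3)cc2)c1=O` gives 800 nM and compound 2 `CC[C@@H](C)n1ncn(-c2ccc(N3CCN(c4ccc(OC[C@@H]5CO[C@@](C)(c6ccc(Cl)cc6Cl)O5)cc4)CC3)cc2)c1=O` gives 1560 nM, so the two lie within the scatter of each other. Compound 3 `C[C@]1(c2ccc(Cl)cc2Cl)OC[C@@H](COc2ccc(N3CCN(c4ccc(NC(=O)NN)cc4)CC3)cc2)O1` departs from compound 1 through (a group of 5 heavy atoms (1 carbon, 3 nitrogen, 1 oxygen; no ring) in place of a group of 10 heavy atoms (6 carbon, 3 nitrogen, 1 oxygen; one five-membered aromatic ring with 3 hetero atoms), on an aromatic carbon). For the measured compounds named here, the only measured step, a 2.0-fold higher number from compound 1 to compound 2 (0.29 log units; within the scatter), comes with the fact that compounds 1 and 2 differ only in the configuration as drawn, so it offers no measure for an exchange of this kind. The expectation therefore rests on the structural change alone, and it is a tentative one: a higher number in this assay, an estimated 6.3-fold higher number from compound 1 to compound 3 (0.80 log units; beyond the scatter). For compound 3 the expected value is 5000 nM, with an estimated range of 1000 nM to 25000 nM.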

Compound 3, solubility: 1.4 nM
Compound 3: middle estimate off by 3600-fold (3.55 log units), on the high side; measured number below the stated range.
By their numbers in this assay, from the lowest: compound 3; then compounds 1 and 2 (each within the scatter of the next).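

In this assay the place on an aromatic carbon, para to a large group, turns out to be far from indifferent: (aminocarbamoyl)amino in place of the ring-bearing group of compound 1 gives a 570-fold lower number from compound 1 to compound 3 (2.76 log units; beyond the scatter) and the earlier pair had left this place unchanged. Nothing in the data at hand speaks to a cause of this step. For the compounds shown here, the single exchange removes the five-membered aromatic ring and brings in the new group together, and the two remain unseparated. On these data alone, how an amine or a carboxylic acid at this place would read stays open.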